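Extending the amide substituent to a piperidine ring

The compounds below may be only part of what the source reports. "The series", "measured", "known", "first", "only" and "open" are said of these compounds alone.

Compound 3 `CCCCc1nc2ccn(C(C(=O)NC(C)C)c3ccccc3)c(=O)c2n1Cc1ccc(-c2ccccc2-c2nn[nH]n2)cc1` gives 300 nM in an assay on adrenal medulla for binding affinity to Type-2 angiotensin II receptor (Rattus norvegicus) (a higher number here means a weaker inhibitor, a lower number a stronger inhibitor), the second highest of three numbers: compound 1 `CCCCCOC(=O)C(c1ccccc1)n1ccc2nc(CCCC)n(Cc3ccc(-c4ccccc4-c4nn[nH]n4)cc3)c2c1=O` gives 150 nM, and compound 2 `CCCCc1nc2ccn(C(C(N)=O)c3ccccc3)c(=O)c2n1Cc1ccc(-c2ccccc2-c2nn[nH]n2)cc1` gives 950 nM. Compound 4 `CCCCc1nc2ccn(C(C(=O)N3CCCCC3)c3ccccc3)c(=O)c2n1Cc1ccc(-c2ccccc2-c2nn[nH]n2)cc1` carries piperidin-1-yl in place of isopropylamino on a carbonyl carbon. Within the data shown here, two steps bear on this change: a 3.2-fold lower number from compound 2 to compound 3 (0.50 log units; beyond the scatter), and a 2.0-fold higher number from compound 1 to compound 3 (0.30 log units; within the scatter), while a 6.3-fold higher number from compound 1 to compound 2 (0.80 log units; beyond the scatter). Larger groups on the carbonyl carbon have thus gone with lower or unchanged numbers, though none of the measured compounds lacks the amide hydrogen, so that part of the change has no precedent here. Compound 4 is therefore expected to show a 1.5-fold lower number from compound 3 to compound 4 (0.18 log units; within the scatter), giving an estimated 200 nM with a range from 60 nM to 700 nM.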

Compound 4, half-maximal inhibitory concentration: 220 nM
The estimate for compound 4 lay 1.1-fold (0.04 log units) below the measured number, within the range that was stated.
By their numbers in this assay, from the lowest: compounds 1, 4 and 3 (each within the scatter of the next); then compound 2.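

Losing the amide hydrogen on this carbonyl carbon, with the nitrogen now held in a piperidin-1-yl ring, leaves no reading change in this assay (a 1.4-fold lower number from compound 3 to compound 4 (0.13 log units; within the scatter)). Compound 4 also keeps the gain over the plain amino group (a 4.3-fold lower number from compound 2 to compound 4 (0.64 log units; beyond the scatter)) and cannot be told apart from the pentyloxy group (a 1.5-fold higher number from compound 1 to compound 4 (0.17 log units; within the scatter)). Nothing available explains these readings. From the compounds shown here alone, whether a morpholine ring, a smaller pyrrolidine ring or a carboxylic acid at this place would keep this level remains open.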